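Methoxy for fluoro on the pendant phenyl ring

The source may report more compounds than this note shows. Statements on the series, on what has been measured and on what is new or still open speak of the compounds shown alone.

Measured compounds:
compound 1, `Cc1ccc(-c2ccc(C)n2-c2ccc(-c3nc4ccccc4s3)cc2)cc1`, 3100 nM
compound 2, `Cc1ccc(-c2ccc(F)cc2)n1-c1ccc(-c2nc3ccccc3s2)cc1`, 3180 nM

Both compounds share one core and differ only in the group on the pendant phenyl ring. In a functional assay on MCF7 cells (Homo sapiens) for cytotoxicity, read by MTT assay, with a stated time of 72 h (a higher number here means a weaker inhibitor, a lower number a stronger inhibitor), compound 1 gives 3100 nM and compound 2 gives 3180 nM; the step of a 1.0-fold higher number from compound 1 to compound 2 (0.01 log units; within the scatter) sits within the scatter, so the two values cannot be told apart.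

Compound 3, `COc1ccc(-c2ccc(C)n2-c2ccc(-c3nc4ccccc4s3)cc2)cc1`, is not yet measured. It differs from compound 2 by methoxy in place of fluoro on an aromatic carbon. Among the measured compounds shown here, the only measured step, a 1.0-fold higher number from compound 1 to compound 2 (0.01 log units; within the scatter), exchanges one small group for another at this same carbon and leaves the number unchanged beyond the scatter. Nothing measured here distinguishes the methoxy group from the groups already tried at that carbon, so no step beyond the scatter is expected for compound 3 in this assay, the expected step being a 1.1-fold lower number from compound 2 to compound 3 (0.03 log units; within the scatter). Compound 3 is therefore estimated at 3000 nM, with a range of 1200 nM to 7500 nM.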

Compound 3, half-maximal inhibitory concentration: 3260 nM
For compound 3 the middle estimate is 1.1-fold (0.04 log units) below the measured one, within the range that was stated.
By their numbers in this assay, from the lowest: compounds 1, 2 and 3 (each within the scatter of the next).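

Methoxy is the third group at this carbon, para to a large group, and in this assay it does not separate from either earlier group: the step is a 1.0-fold higher number from compound 2 to compound 3 (0.01 log units; within the scatter) and, against the methyl group, a 1.1-fold higher number from compound 1 to compound 3 (0.02 log units; within the scatter). The earlier pair showed only that fluoro and methyl could not be told apart, whereas this exchange of 4-fluorophenyl for 4-methoxyphenyl adds a second heavy atom and a hydrogen-bond acceptor with no step beyond the scatter. Nothing available explains this flat result.

From the compounds shown here alone, whether the position stays as flat with an amine, a carboxylic acid or a longer chain such as butoxy remains open. The compounds shown also leave open whether the same holds with a charged group at this carbon or in any other cell line.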